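The source may hold more compounds than are shown below. What is called first, only, known or untested is meant among the compounds shown, and "the series" means these compounds.

Measured so far:
compound 1 `COc1ccc(OC(=O)Nc2ccc([Se]C#N)cc2)cc1`, in a functional assay on CCRF-CEM cells (Homo sapiens) for cytotoxicity, read by MTT assay, with a stated time of 72 h (on this read-out lower numbers stand for higher toxicity in this test and higher numbers for lower toxicity in this test), compound 1 gives 70000 nM
compound 2 `CC(C)COC(=O)Nc1ccc([Se]C#N)cc1`, in this assay compound 2 gives 68700 nM

Of the two numbers in this assay, compound 2 has the lower one, but its nearest neighbour is compound 1, and the two values stand within the scatter of each other, so the two compounds cannot be told apart in this assay. Both share the same core and differ only in the group attached through the carbamate oxygen.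

The compound not yet measured is compound 3 `CCOC(=O)Nc1ccc([Se]C#N)cc1`. It differs from compound 2 in one place: methyl in place of isopropyl on a saturated chain carbon bound to an oxygen next to a carbonyl group, that is, a methyl in place of isopropyl on a saturated chain carbon bound to an oxygen next to a carbonyl group. For the measured compounds named here, no step between measured compounds shows what such a change does in this assay. Given that compound 1 and compound 2 carry quite different groups at this position and still give values within the scatter, the expectation for compound 3 is a step no larger than the scatter, in no particular direction, as expressed by a 1.0-fold higher number from compound 2 to compound 3 (0.01 log units; within the scatter). The estimate for compound 3 in this assay is therefore 70000 nM, with a range from 35000 nM to 140000 nM.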

Compound 3, concentration lethal to 50% of the cells: 68800 nM
Beside the measured number, compound 3's estimate is 1.0-fold (0.01 log units) above it; measured number inside the range.
By their numbers in this assay, from the lowest: compounds 2, 3 and 1 (each within the scatter of the next).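

In this assay, for the compounds shown here, the change to methyl in place of isopropyl on a saturated chain carbon bound to an oxygen next to a carbonyl group gives a 1.0-fold higher number from compound 2 to compound 3 (0.00 log units; within the scatter), and this is the first step at this position that can be read directly. It shows that, between this pair of compounds, isobutoxy and ethoxy cannot be told apart in this test, so the loss of two carbon atoms from the group leaves no visible mark on the read-out. Nothing available accounts for this result, which stands as an observation only.

The compounds shown leave open whether any group on this oxygen can move the number beyond the scatter, for instance a chain ending in an amine or a carboxylic acid, or a much longer chain such as octyl. They also leave open what a change in the shared core would do, since all three compounds carry it unchanged and only the group on the carbamate oxygen differs among them.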